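Tribromophenyl in place of bromomethylphenyl on the sulfonamide

The compounds below may be only part of what the source reports. "The series", "measured", "known", "first", "only" and "open" are said of these compounds alone.

Of the compounds shown here, three sharing one core have been measured in an assay on isolated protein for binding affinity to 5-hydroxytryptamine receptor 6 (Homo sapiens); on this read-out higher numbers stand for weaker inhibition and lower numbers for stronger inhibition. Compound 1 `COc1ccc(S(=O)(=O)Nc2cc(Br)cc(Br)c2)cc1N1CCNCC1` gives 0.501 nM. Compound 2 `COc1ccc(S(=O)(=O)Nc2ccc(C)cc2Br)cc1N1CCNCC1` gives 7.94 nM, the highest of the three numbers. Compound 3 `COc1cc(Cl)c(C)cc1NS(=O)(=O)c1ccc(OC)c(N2CCNCC2)c1` gives 2 nM, a value that lies below that of compound 2 by more than the scatter.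

For the measured compounds named here, the one measured step that bears on the change at hand is a 16-fold higher number from compound 1 to compound 2 (1.20 log units; beyond the scatter): exchanging the dibrominated ring for the bromomethyl ring raised the number sharply. Compound 4 `COc1ccc(S(=O)(=O)Nc2cc(Br)cc(Br)c2Br)cc1N1CCNCC1` carries 2,3,5-tribromophenyl in place of 2-bromo-4-methylphenyl on a sulfonamide nitrogen. This change moves back toward a ring bearing bromine atoms only and adds a third bromine beyond what compound 1 holds.

Given the size of the step from compound 1 to compound 2, compound 4 is expected to return to a number near that of compound 1, so that the step from compound 2 to compound 4 is estimated as a 7.9-fold lower number from compound 2 to compound 4 (0.90 log units; beyond the scatter) in this assay. The value of compound 4 is therefore estimated at 1 nM, with a range from 0.3 nM to 4 nM.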

Compound 4, inhibition constant: 2.51 nM
For compound 4 the middle estimate is 2.5-fold (0.40 log units) below the measured one; low and high end bracket the measured number.
By their numbers in this assay, from the lowest: compound 1; then compounds 3 and 4 (each within the scatter of the next); then compound 2.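

In this assay, 2,3,5-tribromophenyl in place of 2-bromo-4-methylphenyl on a sulfonamide nitrogen gives a 3.2-fold lower number from compound 2 to compound 4 (0.50 log units; beyond the scatter), so a ring bearing only bromine recovers part, but not all, of what the earlier step away from 3,5-dibromophenyl lost. Bromo in place of hydrogen on an aromatic carbon gives a 5.0-fold higher number from compound 1 to compound 4 (0.70 log units; beyond the scatter), which shows that in this pair the third bromine goes with a higher number, not a lower one. Nothing measured here accounts for either step.

The compounds shown do not tell whether this rise is specific to bromine or would also follow a nitrile, a trifluoromethyl group or an amine on that same carbon. Also open, as far as these compounds go, is what a plain phenyl on the sulfonamide nitrogen would give as a baseline for these brominated rings.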